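This account rests on a few compounds, and the source may have more. Where it says the series, first, only, none or still open, it means among the compounds named here.

Measured so far in a functional assay on NCI-H522 cells (Homo sapiens) for cytotoxicity, read by sulforhodamine B assay, with a stated time of 48 h, tested at 0.01 uM; a lower number here means a stronger effect, a higher number a weaker effect of the compound at the concentration tested:
- compound 1, `COc1cc(C)cc(-c2c(-c3ccnc(-c4ccc(N(C)C)cc4)c3)cnn2CC#N)c1`: -7%
- compound 2, `COc1cc(C)cc(-c2nn(CC#N)cc2-c2ccnc(-c3ccc(N(C)C)cc3)c2)c1`: 87%
- compound 3, `COc1cc(C)cc(-c2nn(CC#N)cc2-c2ccc(-c3cccc(C(C)=O)c3)nc2)c1`: 82%

Compound 2 stands at the highest of the three numbers in this assay. Its value and that of compound 3 lie within the usual scatter of each other, so no order between the two is claimed. Among the compounds with values here, compound 1 sits far lower, beyond the scatter, and shares with compound 2 only a rearrangement of the same pieces around the core; no single-point step connects any pair of the measured compounds.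

The next compound, compound 4, `Cc1cc(O)cc(-c2nn(CC#N)cc2-c2ccnc(-c3ccc(N(C)C)cc3)c2)c1`, is derived from compound 2 by one change: hydrogen in place of methyl on an oxygen on an aromatic ring The methoxy of compound 2 becomes a hydroxy on the same phenyl ring, with the rest of the molecule kept.

Within the data shown here, no measured step of this kind exists, so the expectation rests on compound 2 alone. Compound 4 is expected to stay close to compound 2, with the step from compound 2 to compound 4 estimated at a number 7 percentage points lower from compound 2 to compound 4 (within the scatter), most likely no change beyond the scatter, with a slight downward lean. The estimate for compound 4 in this assay is 80%, with a range from 55% to 100%.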

Compound 4, a percentage reported as activity, at one concentration (the size of the read-out at that concentration, not a potency): 84%
Compound 4: the middle estimate sits 4 percentage points below what was measured; low and high end bracket the measured number.
By their numbers in this assay, from the lowest: compound 1; then compounds 3, 4 and 2 (each within the scatter of the next).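

In this assay, the series now has its first single-point step, a number 3 percentage points lower from compound 2 to compound 4 (within the scatter), and it concerns hydrogen in place of methyl on an oxygen on an aromatic ring. The 3-methoxy-5-methylphenyl and 3-hydroxy-5-methylphenyl forms therefore cannot be told apart by this read-out, at least in this one pair with the rest of the molecule kept, and the methyl on that oxygen is shown not to be needed for the read-out to stay within the scatter of compound 2. No supporting information bears on this result.

From the compounds shown here alone, whether the oxygen position tolerates a larger group such as ethoxy or benzyloxy, or a replacement of the oxygen by an amine, remains open, as does the role of the methyl on the same phenyl ring. Going by these compounds, the read-out is also a size at one concentration rather than a potency, so whether compound 2 and compound 4 would separate at other concentrations stays open too.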